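Shortening a Chain on an Aziridine Quinone Carbamate

This account rests on a few compounds, and the source may have more. Where it says the series, first, only, none or still open, it means among the compounds named here.

Two compounds share a core carrying two aziridine rings on a quinone. Compound 1 `CCCC1=C(N2CC2)C(=O)C(C(COC(N)=O)OC)=C(N2CC2)C1=O` bears a propyl chain and a carbamate-containing side chain, while compound 2 `COCCC1=C(N2CC2)C(=O)C(C)=C(N2CC2)C1=O` bears a methoxyethyl chain and a methyl group. Both were tested in a functional assay on L1210 cells (Mus musculus), with a stated time of 1 days (on this read-out higher numbers stand for higher potency (the scale is a negative logarithm) and lower numbers for lower potency), where compound 1 gives 5.01 and compound 2 gives 5.19. Compound 1 stands as the lower of the two numbers, but the gap to compound 2 is within the scatter, so the two values should be read as alike.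

Compound 3 `CCC1=C(N2CC2)C(=O)C(C(COC(N)=O)OC)=C(N2CC2)C1=O` has not yet been measured. Compared with compound 1, the change is hydrogen in place of methyl on a saturated chain carbon, two bonds along the chain from a double-bonded ring carbon. Within the data shown here, no pair of measured compounds differing only in this way is available, so the size of the step must be guessed from the smallness of the change. The removal of a single carbon from a saturated chain is expected to move the value little, if at all, beyond the scatter in either direction.

Compound 3 is therefore expected to give about 5, between 4.5 and 5.5, in this assay. This expectation corresponds to a step of a number 0.01 log units lower from compound 1 to compound 3 (within the scatter).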

Compound 3, logarithm of the reciprocal of the active concentration, log(1/C): 5.62
Estimate against measurement, compound 3: 0.62 log units below, and the stated range ends below it.
By their numbers in this assay, from the lowest: compounds 1 and 2 (each within the scatter of the next); then compound 3.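

Shortening the propyl chain to an ethyl chain on the shared core gives, in this assay, a number 0.61 log units higher from compound 1 to compound 3 (beyond the scatter). This saturated chain carbon, two bonds along the chain from a double-bonded ring carbon, is therefore a place where the loss of one carbon can be seen in the potency, even though the change is a small one. Compound 2 could not show this, since it differs from compound 1 in more than one place, and no measurement of any other property is available to explain the step.

Among these compounds, a single step links only two chain lengths, so it stays open whether potency would keep rising with a still shorter chain at this place, or whether a longer chain such as butyl would give a lower number than propyl. Going by these compounds, it also stays open whether an ethyl chain ending in an amine or a carboxylic acid would hold the higher value, and whether the same shortening would matter with another side chain in place of the carbamate-containing one.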